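The source may report more compounds than this note shows. Statements on the series, on what has been measured and on what is new or still open speak of the compounds shown alone.

Measured in an ADME assay on THP-1 cells (Homo sapiens) for cytotoxicity (a lower number here means a stronger inhibitor, a higher number a weaker inhibitor), so far:
compound 1 `COc1ccccc1-c1nnc(-c2ccc(C(=O)N/N=C/c3ccc(F)cc3)cc2)o1` gives 427000 nM
compound 2 `COc1ccccc1-c1nnc(-c2ccc(C(=O)N/N=C/c3ccc(O)c(O)c3)cc2)o1` gives 100000 nM
compound 3 `COc1ccc(/C=N/NC(=O)c2ccc(-c3nnc(-c4ccccc4OC)o3)cc2)c(O)c1` gives 308000 nM

Compound 1 stands at the highest number of the three. Compound 3 sits within the scatter of it, as the step of a 1.4-fold lower number from compound 1 to compound 3 (0.14 log units; within the scatter) shows, while compound 2 is set apart by the step of a 4.3-fold lower number from compound 1 to compound 2 (0.63 log units; beyond the scatter). Between those two, the step of a 3.1-fold higher number from compound 2 to compound 3 (0.49 log units; beyond the scatter) also passes the scatter.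

Compound 4 `COc1ccccc1-c1nnc(-c2ccc(C(=O)N/N=C/c3ccc(O)cc3)cc2)o1` differs from compound 1 in one place: hydroxy in place of fluoro on an aromatic carbon. For the measured compounds named here, the steps that bear on this are the two that also put hydroxy onto the same ring in place of fluoro: the step from compound 1 to compound 2, where two hydroxy groups enter, and the step from compound 1 to compound 3, where one hydroxy enters together with a methoxy. The first is modest and beyond the scatter, the second within it. A single hydroxy is expected to land between these, so a small step downward is expected, a 1.7-fold lower number from compound 1 to compound 4 (0.23 log units; within the scatter), possibly no more than the scatter. Compound 4 is therefore estimated at 250000 nM, with a range from 120000 nM to 500000 nM.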

Compound 4, half-maximal inhibitory concentration: 261000 nM
The estimate for compound 4 lay 1.0-fold (0.02 log units) below the measured number, and the stated range covers the measured number.
By their numbers in this assay, from the lowest: compound 2; then compounds 4, 3 and 1 (each within the scatter of the next).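

In this assay, hydroxy in place of fluoro on this aromatic carbon, para to a large group, stays within the scatter (a 1.6-fold lower number from compound 1 to compound 4 (0.21 log units; within the scatter)), so a single hydroxy here cannot be told apart from fluoro. Exchanging the 2-hydroxy-4-methoxyphenyl group for 4-hydroxyphenyl also stays within the scatter (a 1.2-fold lower number from compound 3 to compound 4 (0.07 log units; within the scatter)). For the compounds shown here, only the step that removes one hydroxy from the 3,4-dihydroxyphenyl group passes it (a 2.6-fold higher number from compound 2 to compound 4 (0.42 log units; beyond the scatter)), which places the separation of compound 2 with the pair of hydroxy groups rather than with hydroxy as such.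

The compounds shown leave open whether an amine or a carboxylic acid in place of this hydroxy would move the number beyond the scatter. No evidence available here gives a reason for any of these steps.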